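Two fluorines for a methyl on a shared aryl ring

The source may hold more compounds than are shown below. What is called first, only, known or untested is meant among the compounds shown, and "the series" means these compounds.

Compound 1 `CC(=O)Oc1ccc2cc(-n3cc(-c4ccc(C)cc4)nn3)c(=O)oc2c1C` was tested in a functional assay on MCF7 cells (Homo sapiens) for antiproliferative activity; on this read-out higher numbers stand for weaker inhibition and lower numbers for stronger inhibition. Its value of > 100000 nM is a limit of the assay rather than a number. Compound 3 `CC(=O)Oc1ccc2cc(-n3cc(-c4ccc(F)cc4F)nn3)c(=O)oc2c1C` differs from compound 1 by 2,4-difluorophenyl in place of 4-methylphenyl on an aromatic carbon. In this assay compound 3 also reaches only a limit, > 100000 nM. The step that the two limits leave unreadable from compound 1 to compound 3 therefore cannot be read. Compound 2 `CO[C@@H]1[C@@H](O)[C@@H](O)[C@H](Oc2ccc3c(c2C)OC(=O)C(n2cc(-c4ccc(C)cc4)nn2)C3)OC1(C)C` has a different core; how its core differs from that of compound 1 is not broken down here. In this assay compound 2 likewise gives a limit, > 100000 nM. All three measured values thus sit at the limit of > 100000 nM in this assay, at which 3 of the 3 values shown sit. Compound 4 `CO[C@@H]1[C@@H](O)[C@@H](O)[C@H](Oc2ccc3c(c2C)OC(=O)C(n2cc(-c4ccc(F)cc4F)nn2)C3)OC1(C)C` has not yet been measured; it differs from compound 2 by 2,4-difluorophenyl in place of 4-methylphenyl on an aromatic carbon, the same change, at the same place, as that made from compound 1 to compound 3. From compound 2 the expected step that the limit leaves unreadable from compound 2 to compound 4 is small, because a step that the two limits leave unreadable from compound 1 to compound 3 gave no readable step between two values at the limit. Compound 4 is therefore expected to give about 150000 nM, most likely once more only a limit, within an estimated range from 50000 nM to 500000 nM.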

Compound 4, half-maximal inhibitory concentration: > 100000 nM
Compound 4 gave a limit, no number; the forecaster's own chance of this, stated with the estimate: 85%; the middle value does not contradict the limit.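

Compound 2 and compound 4 both give only a limit in this assay, not a number, and the step between them, 2,4-difluorophenyl in place of 4-methylphenyl, cannot be read. The compounds shown leave open how either aryl group or either core would compare on these cells, because every value sits at one limit: the limit of > 100000 nM in this assay, at which 4 of the 4 values shown sit.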